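Changing the Link on the Carbonyl Carbon: Compound 3

The source may report more compounds than this note shows. Statements on the series, on what has been measured and on what is new or still open speak of the compounds shown alone.

Measured so far:
compound 1, `O=C(Nc1cccc(-n2cc(-c3ccncc3)c(-c3ccc(Cl)c(O)c3)n2)c1)Nc1ccc(Cl)c(Cl)c1`: 3160 nM
compound 2, `COc1cc(-c2nn(-c3cccc(NC(=O)c4ccc(Cl)c(C(F)(F)F)c4)c3)cc2-c2ccncc2)ccc1Cl`: > 32500 nM

Both were tested in a functional assay on UACC-257 cells (Homo sapiens) for inhibition, read by sulforhodamine B assay, with a stated time of 48 h; on this read-out higher numbers stand for weaker inhibition of growth and lower numbers for stronger inhibition of growth. Compound 1 gives 3160 nM. For compound 2 the assay reports only a limit, > 32500 nM, not a number. Compound 2 thus stands at the limit of > 32500 nM in this assay, at which 1 of the 2 values shown sits.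

Compound 3 `COc1cc(-c2nn(-c3cccc(NC(=O)Nc4cccc(C(F)(F)F)c4)c3)cc2-c2ccncc2)ccc1Cl` differs from compound 2 in one place: (3-(trifluoromethyl)phenyl)amino in place of 4-chloro-3-(trifluoromethyl)phenyl on a carbonyl carbon. Going by the values given here, no measured pair shows this change, so its size is unknown. Since compound 2 sits at the limit, a step is expected only toward stronger growth inhibition, if any; the expected step is an at least 2.7-fold lower number from compound 2 to compound 3 (0.43 log units; beyond the scatter). Compound 3 is estimated at 12000 nM, between 3000 nM and 40000 nM.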

Compound 3, concentration for total growth inhibition: 2310 nM
Estimate against measurement, compound 3: 5.2-fold (0.72 log units) above, and the stated range ends above it.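

In this assay, putting (3-(trifluoromethyl)phenyl)amino in place of 4-chloro-3-(trifluoromethyl)phenyl on the carbonyl carbon gives an at least 14-fold lower number from compound 2 to compound 3 (1.14 log units; beyond the scatter). Going by these compounds alone, this is the first step read at this position, and it shows that a change here can shift growth inhibition strongly. Compound 2 has only a limit, not a number: the limit of > 32500 nM in this assay, at which 1 of the 3 values shown sits.

The change adds an amino nitrogen and removes the chlorine of the leaving group together, so the compounds shown cannot tell which of the two carries the step. Going by these compounds, whether a methylene group in that nitrogen's place would keep the step also stays open.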